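Methyl in Place of Hydrogen: Expected Solubility of Compound 4

The source may report more compounds than this note shows. Statements on the series, on what has been measured and on what is new or still open speak of the compounds shown alone.

Three compounds have been measured in a physicochemical assay for solubility, read by HPLC, in simulated intestinal fluid, measured as thermodynamic solubility, with a stated time of 24 h; a higher number here means a more soluble compound, a lower number a less soluble compound:
compound 1, `O=S(=O)(Nc1cccc(CO)c1)c1ccc(-c2ccc(Br)cc2)cc1`, gives 22 ug/mL;
compound 2, `O=S(=O)(Nc1cccc(CO)c1)c1ccc(-c2ccc(F)cc2F)cc1`, gives 50 ug/mL;
compound 3, `Cc1c(CO)cccc1NS(=O)(=O)c1ccc(-c2ccc(F)cc2F)cc1`, gives 43 ug/mL.

Compound 1 holds the lowest of the three numbers. Its core differs from that of compound 2 by 4-bromophenyl in place of 2,4-difluorophenyl on an aromatic carbon, and in this assay a 2.3-fold higher number from compound 1 to compound 2 (0.36 log units; beyond the scatter). On the core of compound 2, a methyl entered in place of hydrogen, (methyl in place of hydrogen on an aromatic carbon), and a 1.2-fold lower number from compound 2 to compound 3 (0.07 log units; within the scatter).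

Compound 4, `Cc1ccc(CO)cc1NS(=O)(=O)c1ccc(-c2ccc(Br)cc2)cc1`, has not yet been measured. It carries the same kind of change on the core of compound 1: methyl in place of hydrogen on an aromatic carbon. The surroundings are not identical: in compound 3 the methyl sits ortho to a hydroxymethyl group and ortho to a large group, whereas in compound 4 it sits ortho to a large group and para to a hydroxymethyl group.

The expected step from compound 1 to compound 4 rests on compound 3, whose step a 1.2-fold lower number from compound 2 to compound 3 (0.07 log units; within the scatter) stayed within the scatter, so a step of a 1.2-fold lower number from compound 1 to compound 4 (0.06 log units; within the scatter) is expected. Compound 4 is therefore estimated at 19 ug/mL, with a likely range from 8 ug/mL to 42 ug/mL.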

Compound 4, solubility: 47 ug/mL
Compound 4: middle estimate off by 2.5-fold (0.39 log units), on the low side, outside the stated range (above it).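

In this assay, methyl in place of hydrogen on the core of compound 1 gave a 2.1-fold higher number from compound 1 to compound 4 (0.33 log units; beyond the scatter), whereas the same kind of change on the core of compound 2 gave a 1.2-fold lower number from compound 2 to compound 3 (0.07 log units; within the scatter), so the step did not carry unchanged from one core to the other in this pair. This does not show which difference matters, since the two steps differ both in their core and in where the methyl sits, and in compound 4 it lies ortho to a large group and para to a hydroxymethyl group. Nothing available bears on the cause of this result.

The compounds shown leave open whether the methyl at this same place on the core of compound 2 would give a step like that of compound 4, which would separate the role of the core from that of the place. They also leave open how an amine or a methoxy group would behave at this place on either core.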